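The source may report more compounds than this note shows. Statements on the series, on what has been measured and on what is new or still open speak of the compounds shown alone.

Three compounds share one core and differ only in small groups on their outer rings. Compound 1 `O=S(=O)(Nc1nnc(SCc2ccccc2)s1)c1ccccc1` gives 65% in a functional assay on MCF7 cells (Homo sapiens) for cytotoxicity, tested at 250 uM; a higher number here means a weaker effect of the compound at the concentration tested, a lower number a stronger effect. Compound 2 `Cc1ccc(S(=O)(=O)Nc2nnc(SCc3ccccc3)s2)cc1` gives 61% in this assay, and compound 3 `Cc1ccc(S(=O)(=O)Nc2nnc(SCc3ccc(Cl)cc3)s2)cc1` gives 68%. Compound 2 shows the lowest of the three numbers, yet the steps around it are small: a number 4 percentage points lower from compound 1 to compound 2 (within the scatter), and a number 7 percentage points higher from compound 2 to compound 3 (within the scatter), so the three stand level within the usual scatter.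

Compound 4 `COc1ccc(S(=O)(=O)Nc2nnc(SCc3ccccc3)s2)cc1` has not yet been measured. It differs from compound 2 in one place: methoxy in place of methyl on an aromatic carbon. The two measured steps bear on this only loosely, since each swaps one small group for another on an outer ring of the same core, and each stayed within the scatter, a number 4 percentage points lower from compound 1 to compound 2 (within the scatter) and a number 7 percentage points higher from compound 2 to compound 3 (within the scatter). A single small-group change of this kind is therefore expected to leave this assay roughly unchanged, with no step beyond the scatter: an estimated a number 1 percentage points higher from compound 2 to compound 4 (within the scatter). Compound 4 is estimated at 62%, most likely between 50% and 75%.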

Compound 4, a percentage reported as activity, at one concentration (the size of the read-out at that concentration, not a potency): 53%
Estimate against measurement, compound 4: 9 percentage points above; the range from low to high includes it.
By their numbers in this assay, from the lowest: compounds 4, 2, 1 and 3 (each within the scatter of the next, the first and the last beyond it).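

In this assay the change from 4-methylphenyl to 4-methoxyphenyl is small (a number 8 percentage points lower from compound 2 to compound 4 (within the scatter)), so the methoxy and methyl compounds stand level. Methoxy in place of hydrogen, on the aromatic carbon para to a large group, gives the first step in this set that lies beyond the scatter, though a modest one (a number 12 percentage points lower from compound 1 to compound 4 (beyond the scatter)), while methyl in the same place stayed within it (a number 4 percentage points lower from compound 1 to compound 2 (within the scatter)). Nothing available explains this step.

From the compounds shown here alone, it remains open whether an amine or a carboxylic acid at this same place would take the number further from that of compound 1 or bring it back. A longer chain such as ethoxy is also untested in the compounds shown, as is methoxy on the other outer ring.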